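The compounds below may be only part of what the source reports. "The series", "measured", "known", "first", "only" and "open" are said of these compounds alone.

Compound 1, `O=C(/C=C/[C@H]1C[C@@H](O)[C@@H](O)C1)Nc1ccc(F)cc1`: in an ADME assay on S2 cells (Drosophila melanogaster) for cytotoxicity, read by MTT assay (on this read-out higher numbers stand for an effect only at larger amounts of compound and lower numbers for an effect already at smaller amounts), compound 1 gives > 180000 nM, which is a limit of the assay and not a number.
Compound 2, `COc1ccc(NC(=O)/C=C/[C@H]2C[C@@H](O)[C@@H](O)C2)cc1`: in this assay compound 2 gives > 180000 nM, again a limit of the assay rather than a number.

Going by the values given here, compound 2 therefore stands only at a limit in this assay, and so does the one compound it can be compared with. Among the compounds with values here, the single measured step, a step that the two limits leave unreadable from compound 1 to compound 2, cannot be read in size or direction, because both values sit at the limit of > 180000 nM in this assay, at which 2 of the 2 values shown sit. Within the data shown here, no measured step with a readable size bears on the change now considered.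

Compound 3, `CC(C)(C)c1ccc(NC(=O)/C=C/[C@H]2C[C@@H](O)[C@@H](O)C2)cc1`, differs from compound 2 in one place: tert-butyl in place of methoxy on an aromatic carbon. Among the measured compounds shown here, since the only measured step is unreadable and both values shown sit at the same limit, no step beyond the scatter can be expected in either direction; the expectation is simply that compound 3 also reaches the limit, so the expected step is a number no higher from compound 2 to compound 3 (the limit leaves the size open). Compound 3 is estimated at 180000 nM in this assay, with a range from 90000 nM to 360000 nM.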

Compound 3, half-maximal effective concentration: > 180000 nM
Compound 3 was reported as a limit; the forecaster's own chance of this, stated with the estimate: 85%; the middle value sits exactly at the limit.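

Compound 3 also gives only a limit in this assay, so the steps from compound 1 and from compound 2 to compound 3 cannot be read in size or direction: the limit of > 180000 nM in this assay, at which 3 of the 3 values shown sit. The compounds shown leave open what amount of each compound would produce an effect in this assay, and whether fluoro, methoxy or tert-butyl changes that amount at all.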